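The compounds below may be only part of what the source reports. "The series", "measured", "known", "first", "only" and "open" are said of these compounds alone.

Compound 1 `COc1cc[nH]c1/C=C1\C(=O)Nc2ccc(F)c(C#C[C@@H]3CCCN3)c21` gives 31 nM in a functional assay on MDA-MB-435 cells (Homo sapiens) for inhibition; on this read-out lower numbers stand for stronger inhibition and higher numbers for weaker inhibition. Compound 2 `COc1cc[nH]c1/C=C1\C(=O)Nc2ccc(F)c(C#C[C@@H]3C[C@@H](O)CN3)c21` gives 63 nM in this assay.

Among these two numbers compound 2 stands highest, with compound 1 the nearest. Compound 3 `COc1cc[nH]c1/C=C1\C(=O)Nc2ccc(F)c(C#C[C@@H]3C[C@H](O)CN3)c21` differs from compound 2 in one respect: the two compounds have the same atoms and bonds and differ only in configuration as drawn: 1 of 3 stereo elements differ; a stereocentre at a saturated ring carbon is drawn R in compound 2 and S in compound 3. Going by the values given here, the single measured step, a 2.0-fold higher number from compound 1 to compound 2 (0.31 log units; beyond the scatter), concerns the hydroxy entering and says nothing about its configuration, so no measured step bears directly on this change. Compound 3 is therefore expected to stay close to compound 2, with no change at the digits printed from compound 2 to compound 3 (within the scatter) and no step beyond the scatter. The estimate for compound 3 is 63 nM, between 28 nM and 140 nM.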

Compound 3, half-maximal inhibitory concentration: 110 nM
Compound 3: the middle estimate sits 1.7-fold (0.24 log units) below what was measured; low and high end bracket the measured number.
By their numbers in this assay, from the lowest: compound 1; then compounds 2 and 3 (each within the scatter of the next).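

Turning over the hydroxy-bearing stereocentre gives, in this assay, a 1.7-fold higher number from compound 2 to compound 3 (0.24 log units; within the scatter), so the two configurations cannot be told apart on this read-out. Hydroxy in place of hydrogen on a saturated ring carbon also gives a step beyond the scatter when drawn S, with a 3.5-fold higher number from compound 1 to compound 3 (0.55 log units; beyond the scatter), so the earlier rise is not confined to the R configuration. The pair isolates a single structural variable: the fact that compounds 2 and 3 differ only in the configuration as drawn

The compounds shown leave open how other groups on this saturated ring carbon, such as an amine, a methoxy or a carboxylic acid, would read out in this assay.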